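A few compounds are considered here, and "the series" means these few. Any claim that something is new, unique, unknown or untested is made for them only; others in the source may bear on it.

Measured compounds:
- compound 1, `CCc1nc(N)c2nc(O)n(Cc3ccccc3)c2n1`: 1 uM
- compound 2, `Nc1ncnc2c1nc(O)n2C1CCCC1`: > 10 uM
- compound 3, `COc1ccccc1Cn1c(O)nc2c(N)ncnc21`: 10 uM

Of the compounds shown here, three built on the shared core have been tested in a functional assay (spleen, spleen) for activation, with Mus musculus as the target; on this read-out higher numbers stand for an effect only at larger amounts of compound and lower numbers for an effect already at smaller amounts. Compound 1 gives 1 uM, the lowest of the two numbers recorded. Compound 3 gives 10 uM, a higher number than that of compound 1 and a difference that lies beyond the usual scatter. For compound 2 the read-out is a limit of the assay, not a number: compound 2 gives > 10 uM, as noted in the limit of > 10 uM in this assay, at which 1 of the 3 values shown sits.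

Compound 4, `CCCCc1nc(N)c2nc(O)n(Cc3ccccc3)c2n1`, has not yet been tested in this assay. It differs from compound 1 by ethyl in place of hydrogen on a saturated chain carbon, two bonds along the chain from an aromatic carbon. Within the data shown here, no step between measured compounds matches this change, so the expectation rests on compound 1 alone. The account expects the step from compound 1 to compound 4 to be small, a 2.0-fold lower number from compound 1 to compound 4 (0.30 log units; within the scatter), towards a somewhat lower number. Compound 4 is therefore estimated at 0.5 uM, with a likely range from 0.1 uM to 3 uM.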

Compound 4, minimum effective concentration: 0.03 uM
Compound 4: middle estimate off by 17-fold (1.22 log units), on the high side, outside the stated range (below it).
By their numbers in this assay, from the lowest: compound 4; then compound 1; then compound 3.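

In this assay, among these compounds, the earlier compounds offered no step at this position, and this first one shows that the chain there has a large bearing on the read-out. Going from ethyl to butyl on the shared core, which is ethyl in place of hydrogen on a saturated chain carbon, two bonds along the chain from an aromatic carbon, gives a 33-fold lower number from compound 1 to compound 4 (1.52 log units; beyond the scatter), so the effect appears at much smaller amounts of compound. None of the information available accounts for the size of this step.

As far as these compounds go, with a single step at this position, it remains open whether propyl would give a number close to that of either compound, or whether a longer chain such as hexyl would continue the direction. From the compounds shown here alone, it is equally open how an amine or a carboxylic acid at the end of the chain would read.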